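Thiourea Benzimidazoles: Does a Smaller Side Chain Change Cytotoxicity?

The compounds below may be only part of what the source reports. "The series", "measured", "known", "first", "only" and "open" are said of these compounds alone.

The study compares four thiourea derivatives that share a benzimidazole-bearing core and differ in the substituent on the thiourea and in the group on the saturated chain carbon. Compound 1 `CC(C)[C@@H](NC(=S)NCc1ccccc1)c1nc2ccccc2[nH]1` carries an isopropyl group on that carbon and a benzyl group on the thiourea. In a functional assay on DU-145 cells (Homo sapiens) for cytotoxicity, read by MTT assay (a higher number here means a weaker inhibitor, a lower number a stronger inhibitor), compound 1 gives 17300 nM. Compound 3 `C[C@@H](NC(=S)NCc1ccccc1)c1nc2ccccc2[nH]1` is obtained from it by the change (methyl in place of isopropyl on a saturated chain carbon bound to an amide-type nitrogen and an aromatic carbon), and in this assay compound 3 gives 28700 nM; the step of a 1.7-fold higher number from compound 1 to compound 3 (0.22 log units; within the scatter) shows that this change leaves the read-out essentially unchanged.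

Compound 2 `CC(C)[C@@H](NC(=S)Nc1cc(C(F)(F)F)cc(C(F)(F)F)c1)c1nc2ccccc2[nH]1` keeps the isopropyl group but carries a different aryl group on the thiourea; the difference between the two cores is not broken down here. In this assay compound 2 gives 20200 nM, which sits close to the values of compound 1 and compound 3.

Compound 4 `C[C@@H](NC(=S)Nc1cc(C(F)(F)F)cc(C(F)(F)F)c1)c1nc2ccccc2[nH]1` has not yet been measured. It arises from compound 2 by the change (methyl in place of isopropyl on a saturated chain carbon bound to an amide-type nitrogen and an aromatic carbon), the same change, at the same place, as from compound 1 to compound 3. Because the step of a 1.7-fold higher number from compound 1 to compound 3 (0.22 log units; within the scatter) was within the scatter, the expected step is a 1.4-fold higher number from compound 2 to compound 4 (0.14 log units; within the scatter). Compound 4 is therefore estimated at 28000 nM in this assay, with a likely range from 12000 nM to 70000 nM.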

Compound 4, half-maximal inhibitory concentration: 17600 nM
Estimate against measurement, compound 4: 1.6-fold (0.20 log units) above; low and high end bracket the measured number.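

In this assay, putting methyl in place of isopropyl on the second core gives a 1.1-fold lower number from compound 2 to compound 4 (0.06 log units; within the scatter), so on this core too the change leaves the read-out essentially unchanged. Set side by side, the two steps do not differ by more than the scatter allows: the same change on two cores in this assay, a 1.7-fold higher number (0.22 log units; within the scatter) from compound 1 to compound 3 and a 1.1-fold lower number (0.06 log units; within the scatter) from compound 2 to compound 4, 1.9-fold (0.28 log units) apart, within the scatter of two such steps. This shows that, across these two cores, the change carried over as a step too small to read, with no sign that the core alters its outcome; it does not show that the two steps share a true size, and it does not show that the change would behave the same way on any core beyond these two.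

The compounds shown leave open whether a longer chain, an amine or a carboxylic acid on the saturated chain carbon, in place of isopropyl or methyl, would move the read-out beyond the scatter. They also leave open whether the same result would hold with something other than benzyl or the trifluoromethyl-bearing aryl group on the thiourea, such as a simple butyl chain or a pyridine ring.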